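The source may hold more compounds than are shown below. What is called first, only, known or untested is meant among the compounds shown, and "the series" means these compounds.

Compound 3 `O=C(O)Cc1sc(C(c2ccc(F)cc2)c2ccc(F)cc2)nc1-c1ccoc1` gives 14 nM in an in vitro assay on HEK385-7 cells for displacement of a labelled ligand from prostaglandin D2 receptor 2 (Homo sapiens); a lower number here means a stronger inhibitor, a higher number a weaker inhibitor. Of the two numbers shown it is the lowest, and the nearest is compound 2 `O=C(O)Cc1sc(C(c2ccc(F)cc2)c2ccc(F)cc2)nc1-c1ccco1`, which gives 18 nM in this assay. Compound 1 `COc1ccc(OC)c(-c2nc(C(c3ccccc3)c3ccccc3)sc2CC(=O)O)c1` reaches only a limit of this assay, > 105 nM (the limit of > 105 nM in this assay, at which 1 of the 3 values shown sits), not a number. Compound 4 `CN(C)c1cc(-c2nc(C(c3ccc(F)cc3)c3ccc(F)cc3)sc2CC(=O)O)ccn1` has not yet been measured. It differs from compound 3 in one place: 2-(dimethylamino)pyridin-4-yl in place of furan-3-yl on an aromatic carbon. Among the compounds with values here, the only measured step at the same place on the shared core is a 1.3-fold lower number from compound 2 to compound 3 (0.11 log units; within the scatter), an exchange of one furan for another that stayed within the scatter. Within the data shown here, that step swapped two closely related five-membered rings, whereas the present change brings in a six-membered ring carrying a dimethylamino group, so no measured step shows how far the number may move. Given how close the two furan compounds sit, the expected step is a 1.4-fold higher number from compound 3 to compound 4 (0.15 log units; within the scatter), a change of moderate size with no firm direction. Compound 4 is therefore estimated at 20 nM, with a range from 5 nM to 80 nM.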

Compound 4, half-maximal inhibitory concentration: 380 nM
Compound 4: the middle estimate sits 19-fold (1.28 log units) below what was measured, outside the stated range (above it).
By their numbers in this assay, from the lowest: compounds 3 and 2 (each within the scatter of the next); then compound 4.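

Placing 2-(dimethylamino)pyridin-4-yl on the aromatic carbon next to the ring nitrogen gives a 27-fold higher number from compound 3 to compound 4 (1.43 log units; beyond the scatter) and a 21-fold higher number from compound 2 to compound 4 (1.32 log units; beyond the scatter), both large steps. Within the data shown here, the exchange of one furan for the other stayed within the scatter, so only this new compound shows that the number can depend strongly on the group held at this position. The data shown give no measured reason for the rise.

This change replaces a five-membered ring with a six-membered one and brings in a dimethylamino group at the same time, and the compounds shown cannot tell these two parts apart. From the compounds shown here alone, whether the rise comes with the six-membered ring or with its substituent remains open, and a plain pyridin-4-yl or phenyl ring at this position would bear directly on that question.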